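Swapping the Anilide Substituent: Expected Cell Tolerance

A few compounds are considered here, and "the series" means these few. Any claim that something is new, unique, unknown or untested is made for them only; others in the source may bear on it.

Compound 1 `Cc1cc(C)cc(S(=O)(=O)n2c(SCC(=O)Nc3ccccc3C)nc3ccccc32)c1` was tested in an ADME assay on MT4 cells (Homo sapiens) for cytotoxicity, read by MTT assay, with a stated time of 5 days (a lower number here means that less compound is tolerated, a higher number that more compound is tolerated), where compound 1 gives 6150 nM. Only one companion has been measured: compound 2 `Cc1cc(C)cc(S(=O)(=O)n2c(SCC(=O)Nc3ccccc3S(N)(=O)=O)nc3ccccc32)c1`, which in this assay gives 25000 nM. On these two numbers compound 1 stands at the lower end, so less of it is tolerated by the cells than of compound 2. Within the data shown here, the single measured step, a 4.1-fold higher number from compound 1 to compound 2 (0.61 log units; beyond the scatter), shows a modest gain in tolerance when a small group was exchanged for a larger one at the same spot.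

Compound 3 `COC(=O)c1ccc(NC(=O)CSc2nc3ccccc3n2S(=O)(=O)c2cc(C)cc(C)c2)cc1` has not yet been measured. It differs from compound 1 in one place: 4-(methoxycarbonyl)phenyl in place of 2-methylphenyl on an amide-type nitrogen. Among the measured compounds shown here, the only step that bears on it is a 4.1-fold higher number from compound 1 to compound 2 (0.61 log units; beyond the scatter), which also exchanged a methyl for a larger group on the same ring and moved the number upward. The incoming group here is different, so the match is loose and the step may be smaller. Still, a rise in the same direction is expected, giving an estimated step of a 1.8-fold higher number from compound 1 to compound 3 (0.25 log units; within the scatter) in this assay. Compound 3 is therefore expected to give about 11000 nM, with a likely range from 4500 nM to 27000 nM.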

Compound 3, half-maximal cytotoxic concentration: 10000 nM
Compound 3: middle estimate off by 1.1-fold (0.04 log units), on the high side; the measured number falls inside the stated range.
By their numbers in this assay, from the lowest: compounds 1 and 3 (each within the scatter of the next); then compound 2.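

In this assay, placing 4-(methoxycarbonyl)phenyl on the amide-type nitrogen instead of 2-methylphenyl gives a 1.6-fold higher number from compound 1 to compound 3 (0.21 log units; within the scatter), so this larger group does not clearly separate the two compounds in cell tolerance. Replacing 2-sulfamoylphenyl with the same group gives a 2.5-fold lower number from compound 2 to compound 3 (0.40 log units; beyond the scatter), which shows that a change at this position can shift the number beyond the scatter and that not every larger group matches compound 2, which has the highest number of the three. No measurement shown here explains why the 2-sulfamoylphenyl group stands apart from the other two groups.

These compounds change the substituent and its place on the ring together, so they cannot show whether the difference between compound 2 and compound 3 comes from the group itself, from where it sits, or from both. From the compounds shown here alone, it also remains open how cell tolerance would respond to a carboxylic acid in place of the methyl ester, or to an amine on the same ring.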